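Trifluoromethyl Added to a Series at the Toxicity Limit

A few compounds are considered here, and "the series" means these few. Any claim that something is new, unique, unknown or untested is made for them only; others in the source may bear on it.

Compound 1 `c1ccc(N2CCc3c(nnn3CC3CC3)C2)cc1` and compound 2 `CCCCCCn1nnc2c1CCN(c1ccccc1)C2` share one core and differ only at the saturated chain carbon bound to an aromatic nitrogen. In an ADME assay on HEL cells (Homo sapiens) for cytotoxicity, read by microscopy, with a stated time of 3 days (on this read-out higher numbers stand for lower toxicity in this test and lower numbers for higher toxicity in this test), compound 1 reaches the limit of the test and gives > 100000 nM. In this assay compound 2 likewise reaches the limit and gives > 100000 nM. The step that the two limits leave unreadable from compound 1 to compound 2 is therefore not readable, and both measured values sit at the limit of > 100000 nM in this assay, at which 2 of the 2 values shown sit. Compound 3 `CCCCCCn1nnc2c1CCN(c1ccc(C(F)(F)F)cc1)C2` departs from compound 2 by trifluoromethyl in place of hydrogen on an aromatic carbon. Among the compounds with values here, no measured step touches the six-membered aromatic ring of carbon only, so the only guide is that compound 2 stands at the limit of this assay and that the one change measured so far, between compound 1 and compound 2, left nothing readable. Compound 3 is therefore expected to remain at or near that limit, with a step of a number no higher from compound 2 to compound 3 (the limit leaves the size open) that is expected to lie within the scatter. The estimate for compound 3 in this assay is 100000 nM, with a range from 40000 nM to 250000 nM.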

Compound 3, minimum cytotoxic concentration: > 100000 nM
Compound 3 gave a limit, no number (the forecaster's own chance of this, stated with the estimate: 75%); the middle value lies on the limit itself.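

In this assay, within the data shown here, compound 3 gives > 100000 nM, which is a limit and not a number, so no step from compound 2 to compound 3 can be read. The compounds shown leave open how far trifluoromethyl or the chain changes toxicity in this test, because all three stand at one value: the limit of > 100000 nM in this assay, at which 3 of the 3 values shown sit.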